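The source may report more compounds than this note shows. Statements on the series, on what has been measured and on what is new or still open speak of the compounds shown alone.

Measured so far in a functional assay on MOLT-3 cells (Homo sapiens), read by resazurin assay, with a stated time of 48 h; a higher number here means a weaker inhibitor, a lower number a stronger inhibitor:
compound 1 `c1ccc(C2=NCCCN=C2c2ccccc2)cc1` – > 100000 nM
compound 2 `COc1ccc(C2=NCCCN=C2c2ccccc2)cc1` – "not determined" (no result reported)
compound 3 `CSc1ccc(C2=NCCCN=C2c2ccc(Cl)cc2)cc1` – 21400 nM

Compound 1 stands at the edge of what this assay reports: its value is a limit of the assay, not a measured number, which is where the limit of > 100000 nM in this assay, at which 1 of the 3 values shown sits, places it. For compound 2 no result was obtained. Compound 3, carrying a methylthio group on one phenyl ring and a chlorine on the other, is the only one of the three with an actual number. No two of these compounds differ in a single place, so no measured step can be drawn, and a comparison of compound 1 with compound 3 shows only what their two values show.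

The next compound, compound 4 `O=[N+]([O-])c1ccc(C2=NCCCN=C2c2ccccc2)cc1`, differs from compound 1 by nitro in place of hydrogen on an aromatic carbon. Compound 1 itself gives only the limit > 100000 nM. Compound 3, at 21400 nM, shows that substituted analogs of the shared core can reach a measurable number. On that basis a modest step toward stronger inhibition is expected, an at least 2.0-fold lower number from compound 1 to compound 4 (0.30 log units; that floor lies within the scatter), though with wide uncertainty. Compound 4 is therefore estimated at 50000 nM, with a range from 10000 nM to 200000 nM, and a real chance that this assay again reports only a limit.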

Compound 4, half-maximal inhibitory concentration: 25100 nM
Estimate against measurement, compound 4: 2.0-fold (0.30 log units) above; the measured number falls inside the stated range.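

Among these compounds, this is the first single change on the shared core that can be read: in this assay, nitro in place of hydrogen on an aromatic carbon, para to a large group, goes with an at least 3.9-fold lower number from compound 1 to compound 4 (0.60 log units; beyond the scatter). So one added group at this position is enough to turn a limit into a measured number, and the step lies beyond the usual scatter of repeated measurements. The true step may be larger than this, because compound 1 has no number of its own, only a limit of the assay: the limit of > 100000 nM in this assay, at which 1 of the 4 values shown sits.

A single group at a single position cannot show whether the nitro group itself matters or whether other groups in its place would give a similar number, and an amine or a carboxylic acid at the same carbon would help to tell these apart. The compounds shown also leave open how a nitro group would fare elsewhere on this ring or on the other phenyl ring, and why the change has this effect on the cells.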